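Replacing bromo with thiophen-3-yl on a shared core

The compounds below may be only part of what the source reports. "The series", "measured", "known", "first", "only" and "open" are said of these compounds alone.

Measured so far in an assay on cells for inhibition of S-adenosylmethionine decarboxylase proenzyme (Homo sapiens), read by mass spectrometry, at pH 7.2, tested at 180 uM; on this read-out lower numbers stand for less inhibition and higher numbers for more inhibition at the one concentration tested (going by the name of the read-out):
- compound 1 `Cc1cc(Nc2cc(Cl)cc(Br)c2)nc(N)n1` gives 33%
- compound 2 `CCOc1cc(Br)cc(Nc2cc(C)nc(N)n2)c1` gives 36%

Within the data shown here, compound 1 stands lowest of the two numbers, but its only neighbour, compound 2, sits a number 3 percentage points higher from compound 1 to compound 2 (within the scatter), a step within the scatter, so the two cannot be ordered. That step came from ethoxy in place of chloro on an aromatic carbon.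

Compound 3 `Cc1cc(Nc2cc(Cl)cc(-c3ccsc3)c2)nc(N)n1` has not yet been measured. It differs from compound 1 by thiophen-3-yl in place of bromo on an aromatic carbon. Among the measured compounds shown here, the single measured step touches another position and another pair of groups, so it does not bear directly on this change; it only shows that one swap of a ring substituent on the shared core left this assay within its scatter. For the measured compounds named here, with no step that speaks to thiophen-3-yl in place of bromo, there is no basis for expecting movement beyond the scatter in either direction.

Compound 3 is therefore estimated at about 35%, in a range from 15% to 60%. The expected step is a number 2 percentage points higher from compound 1 to compound 3 (within the scatter).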

Compound 3, a percentage reported as inhibition, at one concentration (the size of the read-out at that concentration, not a potency): 30%
Estimate against measurement, compound 3: 5 percentage points above, within the range that was stated.
By their numbers in this assay, from the lowest: compounds 3, 1 and 2 (each within the scatter of the next).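

Going from bromo to thiophen-3-yl on this aromatic carbon gives a number 3 percentage points lower from compound 1 to compound 3 (within the scatter) in this assay, so this position now has a measured step of its own, where the earlier step spoke only of ethoxy in place of chloro. The swap replaces a single bromine atom with a five-membered aromatic ring that brings a hydrogen-bond acceptor, yet the reading stays within the usual scatter, so this added bulk in atom count leaves no visible mark on this read-out at the one concentration tested. The data offer no measurement that would explain why the number holds steady, so the result stands as an observation only.

Whether an amine, a carboxylic acid or a longer chain on this same carbon would move the reading beyond the scatter remains open, since the groups shown here are only bromo and thiophen-3-yl. Also open, going by these compounds, is how these compounds would compare as full potency values, as a reading at one concentration gives the size of the inhibition there and not a potency.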